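This account rests on a few compounds, and the source may have more. Where it says the series, first, only, none or still open, it means among the compounds named here.

Working notes on the series. For the measured compounds named here, compound 1 `CCCCCC[C@@H](C)NC(=S)Nc1ccc(F)c(Cl)c1` and compound 2 `C[C@H](Nc1nc2cc(Cl)c(F)cc2s1)c1ccc(F)cc1` are the two measured members. In a functional assay on Ehrlich cells (Mus musculus) for cytotoxicity, read by MTT assay, with a stated time of 24 h (a higher number here means a weaker inhibitor, a lower number a stronger inhibitor), compound 1 gives 25500 nM, and compound 2 gives 35400 nM. Compound 1 carries the lower of the two numbers, but the gap to compound 2 lies within the scatter, so the two read alike and no ranking follows from them. Compound 3 `C[C@H](CC1CCCCC1)NC(=S)Nc1ccc(F)c(Cl)c1` is not yet measured. Relative to compound 1 the change is cyclohexyl in place of pentyl on a saturated chain carbon, two bonds along the chain from an amide-type nitrogen; the same difference, cut one bond further out, reads hexyl to cyclohexylmethyl. Going by the values given here, no measured step of this kind exists, so there is nothing to anchor a direction. The expected step is a 1.2-fold lower number from compound 1 to compound 3 (0.06 log units; within the scatter), which is not beyond the scatter. Compound 3 is estimated at 22000 nM in this assay, with a range from 8000 nM to 60000 nM.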

Compound 3, half-maximal inhibitory concentration: 15100 nM
The estimate for compound 3 lay 1.5-fold (0.16 log units) above the measured number, and the stated range covers the measured number.
By their numbers in this assay, from the lowest: compounds 3, 1 and 2 (each within the scatter of the next, the first and the last beyond it).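

In this assay, for the compounds shown here, cyclohexyl in place of pentyl on a saturated chain carbon, two bonds along the chain from an amide-type nitrogen, gives a 1.7-fold lower number from compound 1 to compound 3 (0.23 log units; within the scatter) and so provides the first measured step. At this place, a six-membered non-aromatic ring of carbon only and the open pentyl chain read alike, so this single step sets no direction for the change. No measurement available here accounts for the result.

Still open, from the compounds shown here alone, is whether phenyl, cyclopentyl or a longer chain such as octyl at the same place would give a step beyond the scatter. Also open, going by these compounds, is how an amine or a carboxylic acid carried on that chain would read against compound 1 and compound 3.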